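The source may hold more compounds than are shown below. What is called first, only, known or untested is meant among the compounds shown, and "the series" means these compounds.

Compound 1 `COc1cc(-c2nc(SCc3cn(CC(=O)NC(=O)Nc4ccccn4)nn3)nc(Nc3cccc(C(F)(F)F)c3)c2C#N)cc(OC)c1OC`: 8210 nM
Compound 2 `COc1ccc(Nc2nc(SCc3cn(CC(=O)NC(=O)Nc4ccccn4)nn3)nc(-c3ccc(C)cc3)c2C#N)cc1`: 1700 nM

In a functional assay on MGC-803 cells (Homo sapiens) for inhibition, read by MTT assay, with a stated time of 72 h (a higher number here means a weaker inhibitor, a lower number a stronger inhibitor), compound 2 gives 1700 nM, the lower of the two numbers, while compound 1 gives 8210 nM, a gap beyond the scatter. Compound 3 `Cc1ccc(-c2nc(SCc3cn(CC(=O)NC(=O)Nc4ccccn4)nn3)nc(Nc3cccc(C(F)(F)F)c3)c2C#N)cc1` is not yet measured. The change from compound 2 is 3-(trifluoromethyl)phenyl in place of 4-methoxyphenyl on a nitrogen on an aromatic ring. Among the compounds with values here, no step between measured compounds isolates this change; compound 1 carries the same (3-(trifluoromethyl)phenyl)amino group but differs from compound 2 elsewhere too, so its number is only a loose guide. The expected step is a 2.1-fold higher number from compound 2 to compound 3 (0.31 log units; beyond the scatter), toward a weaker inhibitor, with wide uncertainty. Compound 3 is estimated at 3500 nM, range 1200 nM to 10000 nM.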

Compound 3, half-maximal inhibitory concentration: 7580 nM
The estimate for compound 3 lay 2.2-fold (0.34 log units) below the measured number; the range from low to high includes it.
By their numbers in this assay, from the lowest: compound 2; then compounds 3 and 1 (each within the scatter of the next).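

In this assay, the move from (4-methoxyphenyl)amino to (3-(trifluoromethyl)phenyl)amino is now seen alone, as a 4.5-fold higher number from compound 2 to compound 3 (0.65 log units; beyond the scatter), so the group on this nitrogen counts on the 4-methylphenyl background. With 3-(trifluoromethyl)phenyl on the nitrogen, 4-methylphenyl in place of 3,4,5-trimethoxyphenyl on the aromatic carbon gives a 1.1-fold lower number from compound 1 to compound 3 (0.03 log units; within the scatter), so these two groups are not told apart on that background.

No measurement here bears on the reason for the step. Open, as far as these compounds go, is how an unsubstituted phenyl, a 4-chlorophenyl or a cyclohexyl group on this nitrogen would read, and whether the 3,4,5-trimethoxyphenyl result holds with (4-methoxyphenyl)amino.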